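Working notes: methyl in place of nitro in the series

The source may hold more compounds than are shown below. What is called first, only, known or untested is meant among the compounds shown, and "the series" means these compounds.

- compound 1 `CC(=O)N1N=C(c2ccc3ccccc3c2)OC1c1cccc(Br)c1` gives 2.34 ug/mL in a functional assay on MCF7 cells (Homo sapiens) for antiproliferative activity, read by MTT assay, with a stated time of 48 h; a higher number here means a weaker inhibitor, a lower number a stronger inhibitor
- compound 2 `CC(=O)N1N=C(c2ccc3ccccc3c2)OC1c1ccc([N+](=O)[O-])cc1` gives 7.59 ug/mL in this assay

Compound 2 holds the higher of the two numbers, which makes it the weaker inhibitor of the pair. Compound 3 `CC(=O)N1N=C(c2ccc3ccccc3c2)OC1c1ccc(C)cc1` carries methyl in place of nitro on an aromatic carbon and keeps the shared core. Among the compounds with values here, the one measured step bearing on this is a 3.2-fold higher number from compound 1 to compound 2 (0.51 log units; beyond the scatter) and it is modest, though it alters group and position together. A smaller shift toward a lower number is therefore expected in this assay and it may not clear the scatter. The estimated change is a 1.7-fold lower number from compound 2 to compound 3 (0.23 log units; within the scatter) and nothing firmer is available. Compound 3 is expected at 4.5 ug/mL (estimated range 1.6 ug/mL to 12 ug/mL).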

Compound 3, half-maximal inhibitory concentration: 2.9 ug/mL
Compound 3: middle estimate off by 1.6-fold (0.19 log units), on the high side; low and high end bracket the measured number.
By their numbers in this assay, from the lowest: compounds 1 and 3 (each within the scatter of the next); then compound 2.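

With the position held fixed, this assay shows a 2.6-fold lower number from compound 2 to compound 3 (0.42 log units; beyond the scatter) on the change from nitro to methyl, a comparison of group alone that the earlier step, which altered group and position together, could not give. Across the two aryl variants, a 1.2-fold higher number from compound 1 to compound 3 (0.09 log units; within the scatter) leaves 4-methylphenyl and 3-bromophenyl unseparated, so compound 2 alone stands apart among the three. No measurement available here accounts for the shift.

As far as these compounds go, whether an amine or a carboxylic acid on the same aromatic carbon would fall with compound 2 or with compound 3 remains open.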